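A Methoxy Swap in a Series With Little Spread

A few compounds are considered here, and "the series" means these few. Any claim that something is new, unique, unknown or untested is made for them only; others in the source may bear on it.

Three compounds share one core and differ only in a single group on an aromatic carbon. In an ADME assay on MDCK cells (Canis lupus familiaris) for cytotoxicity, read by MTT assay, with a stated time of 72 h (a higher number here means that more compound is tolerated, a lower number that less compound is tolerated), compound 1 `Cc1nc([N+](=O)[O-])cn1S(=O)(=O)c1ccc(Cl)cc1` gives 578000 nM, compound 2 `CC(=O)Nc1ccc(S(=O)(=O)n2cc([N+](=O)[O-])nc2C)cc1` gives 1030000 nM, and compound 3 `Cc1ccc(S(=O)(=O)n2cc([N+](=O)[O-])nc2C)cc1` gives 988000 nM. Compound 3 lies within the usual scatter of both others, so these numbers do not rank it against them.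

The next structure is compound 4 `COc1ccc(S(=O)(=O)n2cc([N+](=O)[O-])nc2C)cc1`, which has methoxy in place of methyl on an aromatic carbon, para to a large group: methoxy in place of methyl on an aromatic carbon. Among the compounds with values here, no measured compound carries methoxy, so the evidence is indirect. The closest guide is what was seen when methyl took the place of another group at this position: a 1.7-fold higher number from compound 1 to compound 3 (0.23 log units; within the scatter), and a 1.0-fold lower number from compound 2 to compound 3 (0.02 log units; within the scatter). The remaining swap is similarly small: a 1.8-fold higher number from compound 1 to compound 2 (0.25 log units; within the scatter). All three steps stay within the scatter, so no step beyond the scatter is expected in this assay for this change either. The estimated step is a 1.2-fold lower number from compound 3 to compound 4 (0.07 log units; within the scatter). The expected value for compound 4 is 850000 nM, with an estimated range of 450000 nM to 1500000 nM.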

Compound 4, half-maximal cytotoxic concentration: 321000 nM
The estimate for compound 4 lay 2.6-fold (0.42 log units) above the measured number; measured number below the stated range.
By their numbers in this assay, from the lowest: compounds 4, 1, 3 and 2 (each within the scatter of the next, the first and the last beyond it).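

Among the first three compounds, this position on the aromatic ring showed no step beyond the scatter, but methoxy changes that picture in this assay: there is a 3.1-fold lower number from compound 3 to compound 4 (0.49 log units; beyond the scatter) and also a 3.2-fold lower number from compound 2 to compound 4 (0.51 log units; beyond the scatter), so less of compound 4 is tolerated than of either compound 3 or compound 2, though both steps are modest. Methoxy does not stand apart from chloro, however, since a 1.8-fold lower number from compound 1 to compound 4 (0.26 log units; within the scatter) leaves those two compounds unresolved, and the result therefore separates methoxy from methyl and acetamido only. No supporting measurement is available to explain why replacing methyl with methoxy has this effect.

Going by these compounds, whether the step belongs to methoxy alone or is shared by related groups stays open, and a hydroxyl, an ethoxy chain or an amine at the same place would help to settle that. Within the data shown here, with only four compounds, and only one group at this position in each, it also remains open whether a fluoro or a carboxylic acid there would fall with compound 4 or with compound 2.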